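This account rests on a few compounds, and the source may have more. Where it says the series, first, only, none or still open, it means among the compounds named here.

Series in a functional assay on SGC-7901 cells (Homo sapiens) for antiproliferative activity, read by MTT assay, with a stated time of 72 h; a higher number here means a weaker inhibitor, a lower number a stronger inhibitor:
- compound 1 `COc1ccc(-c2ssc(=S)c2-c2cc(OC)c(OC)c(OC)c2)cc1`: 21100 nM
- compound 2 `COc1ccc(-c2c(-c3cc(OC)c(OC)c(OC)c3)ssc2=S)cc1[N+](=O)[O-]`: 44700 nM
- compound 3 `COc1ccc(-c2ssc(=O)c2-c2cc(OC)c(OC)c(OC)c2)cc1`: 134 nM

Compound 3 has the lowest number of the three, beyond the scatter from both compound 1 and compound 2. Compound 4 `COc1ccc(-c2ssc(=O)c2-c2cc(OC)c(OC)c(OC)c2)cc1O` is compound 3 with one change: hydroxy in place of hydrogen on an aromatic carbon. This puts hydroxy in place of hydrogen on an aromatic carbon, ortho to a methoxy group, turning 4-methoxyphenyl into 3-hydroxy-4-methoxyphenyl. For the measured compounds named here, no measured pair shows this change, so the forecast is loosely founded. A moderate fall in the number is expected in this assay, though a result within the scatter remains possible. The expected move is a 2.7-fold lower number from compound 3 to compound 4 (0.43 log units; beyond the scatter). For compound 4 the estimate is 50 nM, with an expected range of 10 nM to 300 nM.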

Compound 4, half-maximal inhibitory concentration: 3110 nM
Estimate against measurement, compound 4: 62-fold (1.79 log units) below, and the stated range ends below it.
By their numbers in this assay, from the lowest: compound 3; then compound 4; then compound 1; then compound 2.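

In this assay, hydroxy in place of hydrogen, turning 4-methoxyphenyl into 3-hydroxy-4-methoxyphenyl, gives a 23-fold higher number from compound 3 to compound 4 (1.37 log units; beyond the scatter). For the compounds shown here, this is the only one-place step, and it shows that this ring position is sensitive to the change, with weaker inhibition as the result. Nothing available accounts for the loss.

Open, from the compounds shown here alone, is whether the loss is specific to hydroxy: an amine or a fluorine at the same position could show that. Also open, going by these compounds, is how hydroxy behaves at other positions on this ring.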